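Swapping a nitro for a methyl on a cytotoxicity series

The source may hold more compounds than are shown below. What is called first, only, known or untested is meant among the compounds shown, and "the series" means these compounds.

Of the compounds shown here, three of one family have been tested in a functional assay on C6 cells (Rattus norvegicus) for cytotoxicity, read by MTT assay, with a stated time of 24 h, tested at 100 ug/mL; on this read-out lower numbers stand for a stronger effect and higher numbers for a weaker effect at the one concentration tested. Compound 1 `Cc1ccc(-c2cs/c(=N/NC(=O)CSc3nnnn3-c3ccccc3)n2-c2ccccc2)cc1` gives 28.5%, compound 2 `Cc1ccc(-c2cs/c(=N/NC(=O)CSc3ncccn3)n2-c2ccccc2)cc1` gives 45.9%, and compound 3 `Cn1nnnc1SCC(=O)N/N=c1/scc(-c2ccc([N+](=O)[O-])cc2)n1-c1ccccc1` gives 64.1%. On these numbers compound 3 stands highest, that is, it has the weakest effect of the three: its gap to compound 2 and its gap to compound 1 both lie beyond the scatter. Among the measured compounds shown here, the only single-point step measured so far is a number 17.4 percentage points higher from compound 1 to compound 2 (beyond the scatter), which concerns a group on the sulfur and not the phenyl ring.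

Compound 4 `Cc1ccc(-c2cs/c(=N/NC(=O)CSc3nnnn3C)n2-c2ccccc2)cc1` has not yet been measured. It differs from compound 3 in one place: methyl in place of nitro on an aromatic carbon. For the measured compounds named here, no measured step covers this change directly, so the expectation rests on what the two values show. Compounds 1 and 2, which both carry the 4-methylphenyl group, give lower numbers than compound 3, which carries the 4-nitrophenyl group. A downward step of moderate size is therefore expected, but with wide uncertainty. For compound 4 the estimate in this assay is 45%, within a range from 27% to 63%, meaning an expected step of a number 19.1 percentage points lower from compound 3 to compound 4 (beyond the scatter).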

Compound 4, a percentage reported as activity, at one concentration (the size of the read-out at that concentration, not a potency): 39.7%
Compound 4: middle estimate off by 5.3 percentage points, on the high side; the measured number falls inside the stated range.
By their numbers in this assay, from the lowest: compound 1; then compounds 4 and 2 (each within the scatter of the next); then compound 3.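

In this assay, among the compounds shown here, the step of a number 24.4 percentage points lower from compound 3 to compound 4 (beyond the scatter) gives the first direct reading of the change from 4-nitrophenyl to 4-methylphenyl: with everything else in the molecule held the same, methyl in place of nitro on this ring goes with a stronger effect at the one concentration tested. The group on the sulfur also gains two direct comparisons: the step of a number 6.2 percentage points lower from compound 2 to compound 4 (within the scatter) leaves 1-methyl-1H-tetrazol-5-yl and pyrimidin-2-yl level, while the step of a number 11.2 percentage points higher from compound 1 to compound 4 (beyond the scatter) shows that methyl in place of phenyl on the aromatic nitrogen of the tetrazole weakens the effect. No measurement at hand explains why either change moves the number.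

On these data alone, the change at the ring rests on one pair of compounds, so it remains open whether the same step would appear with 1-phenyl-1H-tetrazol-5-yl or pyrimidin-2-yl on the sulfur. Also open, as far as these compounds go, is how the effect would respond to other groups at this ring position, such as an amine, a carboxylic acid or a chlorine atom, and whether it would simply follow the same direction.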